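Ring Enlargement at the Amide-Linked Amine

This account rests on a few compounds, and the source may have more. Where it says the series, first, only, none or still open, it means among the compounds named here.

Compound 1 `O=C(CN1CCCC1)Nc1ccc(-c2nc3ccccc3[nH]2)cc1` gives 70000 nM in an ADME assay on MDBK cells (Bos taurus) for cytotoxicity, read by MTT assay, with a stated time of 96 h; a higher number here means that more compound is tolerated, a lower number that less compound is tolerated. Compound 3 `Cn1c(-c2ccc(NC(=O)CN3CCN(c4ccccc4)CC3)cc2)nc2cc(C(F)(F)F)ccc21` gives 1400 nM in this assay, so of the two numbers shown, compound 1 has the higher one, and the gap to compound 3 lies beyond the scatter. Compound 2 `COc1cc(OC)cc(-c2nc3cc(C(F)(F)F)ccc3[nH]2)c1` reaches only the limit of this assay, > 100000 nM, which is a bound rather than a number (the limit of > 100000 nM in this assay, at which 1 of the 3 values shown sits).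

Compound 4 `O=C(CN1CCCCC1)Nc1ccc(-c2nc3ccccc3[nH]2)cc1` differs from compound 1 in one place: piperidin-1-yl in place of pyrrolidin-1-yl on a saturated chain carbon bound to a carbonyl carbon. Going by the values given here, no measured step of this kind is available, so the change is expected to move the number little, if at all, beyond the scatter. The step of a 1.1-fold lower number from compound 1 to compound 4 (0.03 log units; within the scatter) is therefore expected to be small in either direction. Compound 4 is estimated at 65000 nM, within 30000 nM to 100000 nM.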

Compound 4, half-maximal cytotoxic concentration: 18000 nM
Compound 4: the middle estimate sits 3.6-fold (0.56 log units) above what was measured; the whole stated range lies above it.
By their numbers in this assay, from the lowest: compound 3; then compound 4; then compound 1. At a limit, above all of these: compound 2.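

In this assay, this position is not silent: with piperidin-1-yl in place of pyrrolidin-1-yl on the saturated chain carbon bound to a carbonyl carbon, the change from a five-membered to a six-membered ring gives a 3.9-fold lower number from compound 1 to compound 4 (0.59 log units; beyond the scatter). This single-place step lies beyond the scatter, though it is modest in size. No measurement shown bears on what lies behind it.

The compounds shown leave open what a morpholin-4-yl ring or an open-chain diethylamino group would do at this place. On these data alone, whether the same step holds on another core also remains open.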